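A Tolerated Series Under a Cytotoxicity Test

This account rests on a few compounds, and the source may have more. Where it says the series, first, only, none or still open, it means among the compounds named here.

Compound 1 `Cc1ccc2cc(CNCc3ccc(F)cc3)c(=O)[nH]c2c1` in a toxicity assay on MDCK cells (Canis lupus familiaris) for cytotoxicity, read by crystal violet staining, with a stated time of 48 h (a higher number here means that more compound is tolerated, a lower number that less compound is tolerated), gives > 33000 nM, a limit of the assay rather than a number.
Compound 2 `CCCCOc1ccc(CN(Cc2ccc(C(C)(C)C)cc2)Cc2cc3cc(C)ccc3[nH]c2=O)cc1` in this assay gives > 5000 nM, also a limit.
Compound 3 `CCc1ccc2[nH]c(=O)c(CN(Cc3ccc(OC(F)F)cc3)Cc3ccc(C(C)(C)C)cc3)cc2c1` in this assay gives > 5000 nM, also a limit.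

Compound 2 sits at the limit of > 5000 nM in this assay, at which 2 of the 3 values shown sit. Compound 1 sits at the limit of > 33000 nM in this assay, at which 1 of the 3 values shown sits. Compound 2 therefore stands at the lower of the two limits recorded in this assay, with no number of its own. Compound 4 `COc1ccc(C(C)N(Cc2ccc(C(C)(C)C)cc2)Cc2cc3cc(C)ccc3[nH]c2=O)cc1` differs from compound 2 by 1-(4-methoxyphenyl)ethyl in place of 4-butoxybenzyl on an amine nitrogen. Within the data shown here, no measured step pairs these two compounds, and with compound 2 known only as a limit, no change beyond the scatter is expected in this assay; the step that the limit leaves unreadable from compound 2 to compound 4 is expected to be about nil. For compound 4 the expected value in this assay is 8000 nM, within 3000 nM to 30000 nM, most likely again reported as a limit.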

Compound 4, half-maximal cytotoxic concentration: > 5000 nM
Compound 4 was reported as a limit; the forecaster's own chance of this, stated with the estimate: 70%; the middle value does not contradict the limit.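

In this assay compound 4 gives > 5000 nM, a limit. Compound 2 is also known only as a limit, so the step between compound 2 and compound 4 cannot be read. The compounds shown leave open at what concentration any of them becomes cytotoxic.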